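The source may hold more compounds than are shown below. What is called first, only, known or untested is meant among the compounds shown, and "the series" means these compounds.

Compound 1 `COc1cccc(-c2c(C)n(Cc3c(F)cccc3F)c(=O)n([C@@H](C)CNCc3ccccc3)c2=O)c1` gives 370 nM in an assay on HEK293 cells for binding affinity to Gonadotropin-releasing hormone receptor (Homo sapiens); on this read-out lower numbers stand for stronger inhibition and higher numbers for weaker inhibition.
Compound 2 `COc1cccc(-c2c(C)n(Cc3c(F)cccc3F)c(=O)n([C@H](C)CNCc3ccccc3F)c2=O)c1` gives 90 nM in this assay.
Compound 3 `COc1ccc(CNC[C@@H](C)n2c(=O)c(-c3cccc(OC)c3)c(C)n(Cc3c(F)cccc3F)c2=O)cc1` gives 720 nM in this assay.

In this assay compound 3 has the highest of the three numbers. Its number and that of compound 1 lie within the scatter of each other, so no order between these two can be read. The one clear gap is an 8.0-fold higher number from compound 2 to compound 3 (0.90 log units; beyond the scatter).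

Compound 4 `COc1cccc(-c2c(C)n(Cc3c(F)cccc3F)c(=O)n([C@H](C)CNCc3ccc(F)cc3)c2=O)c1` is not yet measured. It differs from compound 3 by fluoro in place of methoxy on an aromatic carbon. For the measured compounds named here, two measured steps bear on this change. a 4.1-fold lower number from compound 1 to compound 2 (0.61 log units; beyond the scatter) shows that a 2-fluorobenzyl group went with a lower number than a plain benzyl group. an 8.0-fold higher number from compound 2 to compound 3 (0.90 log units; beyond the scatter) shows that a 4-methoxybenzyl group went with a higher number than a 2-fluorobenzyl group. Going by the values given here, no measured compound carries a 4-fluorobenzyl group, so how closely compound 4 will follow compound 2 is open. For compound 4 a modest move toward lower numbers is expected, a 3.6-fold lower number from compound 3 to compound 4 (0.56 log units; beyond the scatter). Compound 4 is estimated at 200 nM, with a range from 70 nM to 600 nM.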

Compound 4, inhibition constant: 250 nM
The estimate for compound 4 lay 1.3-fold (0.10 log units) below the measured number; the measured number falls inside the stated range.
By their numbers in this assay, from the lowest: compound 2; then compounds 4, 1 and 3 (each within the scatter of the next, the first and the last beyond it).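

In this assay, the group on this aromatic carbon matters, since a 2.9-fold lower number from compound 3 to compound 4 (0.46 log units; beyond the scatter) shows that fluoro in place of methoxy goes with a lower number. Having a fluorine on the benzyl ring does not settle the outcome. Where it sits also counts: a 2.8-fold higher number from compound 2 to compound 4 (0.44 log units; beyond the scatter) separates the 4-fluorobenzyl group from the 2-fluorobenzyl group. The 4-fluorobenzyl group cannot be told apart from the plain benzyl group, as a 1.5-fold lower number from compound 1 to compound 4 (0.17 log units; within the scatter) lies within the scatter, so these compounds do not show that the fluorine at this place improves on having no substituent.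

Going by these compounds, whether a chloro or hydroxy group on this aromatic carbon would give a number closer to that of compound 2 remains open. No measurement here explains why these groups differ.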